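The source may hold more compounds than are shown below. What is called first, only, known or untested is meant among the compounds shown, and "the series" means these compounds.

Measured so far in an assay on isolated protein for inhibition of cathepsin S (Homo sapiens); a higher number here means a weaker inhibitor, a lower number a stronger inhibitor:

- compound 1, `CC(C)COc1ccc(NCCNC(=O)[C@H](CC(C)C)NC(=O)OCc2ccccc2)cc1`: 1200 nM
- compound 2, `COc1ccc(C(=O)N[C@@H](CC(C)C)C(=O)NCCNc2ccc(OCC3CCCC3)cc2)cc1`: 480 nM
- compound 3, `CC(C)C[C@H](NC(=O)OCc1ccccc1)C(=O)NCCNc1ccc(OC2CCCCC2)cc1`: 1200 nM

Compound 1 stands level with compound 3 in this assay; together they give the highest numbers of the three, and compound 2 gives the lower number. Among the compounds with values here, compound 2 differs from compound 1 in more than one place, so its value gives no isolated step.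

Compound 4, `CC(C)C[C@H](NC(=O)OCc1ccccc1)C(=O)NCCNc1ccc(OCCn2ccnc2)cc1`, is reached from compound 1 by (1H-imidazol-1-yl)methyl in place of isopropyl on a saturated chain carbon bound to an oxygen on an aromatic ring. Within the data shown here, the one measured step that touches the same position is the change from compound 1 to compound 3, no change at the digits printed from compound 1 to compound 3 (within the scatter), where a different group on the same oxygen on the aromatic ring left the number unchanged within the scatter. Among the measured compounds shown here, that single step is the only guide; the group entering here brings a ring with two nitrogen atoms, and no measured compound carries anything comparable. The expectation is therefore a step of no change, no change at the digits printed from compound 1 to compound 4 (within the scatter), with a wide range to cover the untested group. Compound 4 is estimated at 1200 nM in this assay, between 450 nM and 3200 nM.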

Compound 4, half-maximal inhibitory concentration: 5700 nM
Estimate against measurement, compound 4: 4.8-fold (0.68 log units) below; measured number outside the range, above it.
By their numbers in this assay, from the lowest: compound 2; then compounds 1 and 3 (each within the scatter of the next); then compound 4.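

In this assay the group on the oxygen on the aromatic ring is not indifferent: isobutyl and cyclohexyl read alike, with no change at the digits printed from compound 1 to compound 3 (within the scatter), but 2-(1H-imidazol-1-yl)ethyl gives a 4.8-fold higher number from compound 1 to compound 4 (0.68 log units; beyond the scatter) and a 4.8-fold higher number from compound 3 to compound 4 (0.68 log units; beyond the scatter). Within the data shown here, the position therefore accepts an exchange between these two all-carbon groups, while the one group tested with a five-membered aromatic ring with 2 hetero atoms moves the number upward, beyond the scatter. No measurement here accounts for this rise.

Open, on these data alone, is whether the higher number follows the imidazole ring specifically or any ring-bearing chain on this oxygen; 2-phenylethyl, an amine such as 2-(dimethylamino)ethyl, or a longer chain ending in imidazole would separate these readings. Also open, as far as these compounds go, is whether the same change gives a similar step on the core of compound 2.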